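The source may hold more compounds than are shown below. What is called first, only, known or untested is meant among the compounds shown, and "the series" means these compounds.

Compound 1 `COc1cccc(C(=O)Nc2cc(-c3ccccc3)nn2-c2ccccc2)c1` gives 102 nM in a functional assay on cells for positive allosteric modulation of metabotropic glutamate receptor 5 (Rattus norvegicus), read by calcium flux; a higher number here means that more compound is needed for the effect, a lower number that less compound is needed.
Compound 2 `O=C(Nc1cc(-c2ccccc2Cl)nn1-c1ccccc1)c1ccccc1` gives 2290 nM in this assay.
Compound 3 `N#Cc1ccc(C(=O)/N=c2\cc(-c3ccccc3)n(C(=O)c3ccc(C#N)cc3)n2-c2ccccc2)cc1` gives 43 nM in this assay.

Of the compounds shown here, three built on the same core have been measured. Compound 1 stands second highest of the three numbers: its nearest neighbour is compound 3, whose number is lower by a gap that goes beyond the scatter, and its furthest is compound 2, whose number is higher by a gap that goes well beyond the scatter.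

Compound 4 `O=C(CC1CCCC1)Nc1cc(-c2ccccc2)nn1-c1ccccc1` has not yet been measured. It differs from compound 1 in one place: cyclopentylmethyl in place of 3-methoxyphenyl on a carbonyl carbon. Among the compounds with values here, no change of this kind has been measured in this set, so there is no step to lean on. Among the measured compounds, only aromatic groups have been attached at this carbonyl carbon, and the lower numbers of compound 1 and compound 3 both come with such groups. Trading an aromatic group for a non-aromatic one is expected to move the number up by a modest margin, a 4.9-fold higher number from compound 1 to compound 4 (0.69 log units; beyond the scatter). Compound 4 is therefore estimated at 500 nM, with a likely range from 150 nM to 3000 nM.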

Compound 4, half-maximal effective concentration: 350 nM
Beside the measured number, compound 4's estimate is 1.4-fold (0.15 log units) above it; measured number inside the range.
By their numbers in this assay, from the lowest: compound 3; then compound 1; then compound 4; then compound 2.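

Within the data shown here, compound 4 is the first compound here with a non-aromatic ring on this carbonyl carbon, and it still gives a measurable effect in this assay, so an aromatic group at this place is not essential in this pair. Putting cyclopentylmethyl in place of 3-methoxyphenyl costs a modest step, a 3.4-fold higher number from compound 1 to compound 4 (0.54 log units; beyond the scatter), rather than removing the effect. That single swap changes the ring type, the heavy-atom count and the hydrogen-bond acceptor count together, and no supporting measurement shows which of these matters.

As far as these compounds go, whether a cyclohexyl ring or a straight hexyl chain on this carbonyl carbon would give a number nearer that of compound 1 or that of compound 4 remains open. So does the outcome with an amine or a carboxylic acid at the same place.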